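The compounds below may be only part of what the source reports. "The series", "measured", "known", "first", "only" and "open" are said of these compounds alone.

The four compounds share one core: compound 1 (`COc1ccc(-c2c[nH]c(=O)n2-c2cc(OC)c(OC)c(OC)c2)cc1`), compound 2 (`COc1ccc(-c2c[nH]c(=O)n2-c2cc(OC)c(OC)c(OC)c2)cc1N`), compound 3 (`COc1cc(NC(=O)n2cc(-c3ccc(O)cc3)n(-c3cc(OC)c(OC)c(OC)c3)c2=O)cc(OC)c1OC`) and compound 4 (`COc1ccc(-c2cn(C(=O)Nc3cc(OC)c(OC)c(OC)c3)c(=O)n2-c2cc(OC)c(OC)c(OC)c2)cc1`). They are compared in a functional assay on MCF7 cells (Homo sapiens) for cytotoxicity, read by MTT assay, with a stated time of 48 h; on this read-out higher numbers stand for weaker inhibition and lower numbers for stronger inhibition. For compound 1 the entry is "not determined" (no result reported), so it offers no comparison. Compound 2 gives > 50000 nM, which is a limit and not a number. Compound 3 gives > 50000 nM, which is also a limit and not a number. That places compound 3 at the limit of > 50000 nM in this assay, at which 2 of the 3 values shown sit.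

The next compound changes one small detail of compound 3: methyl in place of hydrogen on an oxygen on an aromatic ring. Put simply, 4-hydroxyphenyl becomes 4-methoxyphenyl. Going by the values given here, no measured pair here shows this change alone, which leaves the expectation on thin ground. Compound 2 also carries a methoxy group, and its > 50000 nM is a limit. In this assay, the estimated at least 1.2-fold lower number from compound 3 to compound 4 (0.09 log units; that floor lies within the scatter) is expected to be small, and if it has a direction at all, that would be toward slightly stronger inhibition. Another result reported only as a limit is quite possible. For compound 4 the expected half-maximal inhibitory concentration is 40000 nM, with an estimated range from 5000 nM to 100000 nM.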

Compound 4, half-maximal inhibitory concentration: > 50000 nM
Compound 4 gave a limit, no number; the forecaster's own chance of this, stated with the estimate: 60%; at least 1.2-fold (0.09 log units) between middle value and limit.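

Going by these compounds alone, compound 3 and compound 4 each give a limit and not a number in this assay, so no step between them can be read. The compounds shown leave open whether 4-hydroxyphenyl and 4-methoxyphenyl differ at all in this assay, and what actual number any of these compounds would give: the limit of > 50000 nM in this assay, at which 3 of the 4 values shown sit.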